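The source may hold more compounds than are shown below. What is called first, only, known or untested is meant among the compounds shown, and "the series" means these compounds.

Measured in a functional assay on DU-145 cells (Homo sapiens) for cytotoxicity, read by ELISA, with a stated time of 4 days; a lower number here means a stronger inhibitor, a higher number a weaker inhibitor:
compound 1 `Cc1ccsc1-c1cc(-c2ccco2)cc(-c2ccc(Cl)cc2)n1`: 26700 nM
compound 2 `Cc1ccsc1-c1cc(-c2ccoc2)cc(-c2ccc(Cl)cc2)n1`: 20100 nM
compound 3 `Cc1ccc(-c2cc(-c3ccoc3)cc(-c3ccc(Cl)s3)n2)o1`: 33400 nM

In this assay, compound 3 gives 33400 nM. This value lies within the scatter of the values of both compound 1 and compound 2, so the three compounds cannot be ranked.

The next compound is compound 4 `Clc1ccc(-c2cc(-c3ccoc3)cc(-c3ccccc3Cl)n2)s1`, which has 2-chlorophenyl in place of 5-methylfuran-2-yl on an aromatic carbon.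

Among the compounds with values here, only one measured step is available, a 1.3-fold lower number from compound 1 to compound 2 (0.12 log units; within the scatter). It is a furan-3-yl for furan-2-yl exchange and stays within the scatter. Within the data shown here, it bears on the present change only loosely, as no measured pair covers the replacement of 5-methylfuran-2-yl by 2-chlorophenyl. The closest guide is the narrow spread of the series itself, with compound 1 at 26700 nM and compound 2 at 20100 nM, although these compounds differ from compound 3 in more than one place. No step beyond the scatter is therefore expected in this assay, and no direction can be argued from the data.

The estimate corresponds to a 1.4-fold lower number from compound 3 to compound 4 (0.14 log units; within the scatter), which is expected to stay within the scatter. For compound 4 the expected value is 24000 nM, with an estimated range of 10000 nM to 55000 nM.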

Compound 4, half-maximal inhibitory concentration: 16400 nM
The estimate for compound 4 lay 1.5-fold (0.17 log units) above the measured number; measured number inside the range.
By their numbers in this assay, from the lowest: compounds 4, 2, 1 and 3 (each within the scatter of the next, the first and the last beyond it).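

At the position next to the ring nitrogen, meta to a 5-chlorothiophen-2-yl group and to a furan-3-yl group, 2-chlorophenyl in place of 5-methylfuran-2-yl gives a 2.0-fold lower number from compound 3 to compound 4 (0.31 log units; beyond the scatter) in this assay. Within the data shown here, this is the first single-place change to pass the scatter, whereas the furan-3-yl for furan-2-yl exchange gave only a 1.3-fold lower number from compound 1 to compound 2 (0.12 log units; within the scatter). It shows that this position tolerates a six-membered aromatic ring of carbon only in place of a five-membered aromatic ring with 1 hetero atom without a rise in the number, though the step is modest and compound 4 still reads 16400 nM; no measurement is at hand that would explain the step.

Among these compounds, the single pair cannot separate the contribution of the ring exchange from that of the chlorine on the entering phenyl ring, and it rests on one core only. From the compounds shown here alone, how plain phenyl, an aminomethyl group or a carboxylic acid would read at this position remains open, as does whether the same exchange holds with other neighbouring groups.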